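This account rests on a few compounds, and the source may have more. Where it says the series, first, only, none or still open, it means among the compounds named here.

Working notes on a small series sharing one core. Compound 1 `Cc1ccc2nc(-c3cccc(F)c3)[nH]c(=O)c2c1` was measured in an assay on isolated protein for inhibition of DNA topoisomerase 1 (Homo sapiens), with a stated time of 30 min, tested at 100 uM (on this read-out lower numbers stand for a weaker effect and higher numbers for a stronger effect at the one concentration tested), and there compound 1 gives 82.9%. The second measured member, compound 2 `CCN(CC)c1ccc2nc(-c3ccccc3N(C)C)[nH]c(=O)c2c1`, gives 82.1% in this assay. Compound 1 stands highest of the two numbers, but the gap to compound 2 is within the usual scatter of repeated measurements, so the two values cannot be ordered and neither compound is to be called the stronger one. For the measured compounds named here, no pair of measured compounds differing in one place is available, and compound 2 differs from compound 1 in more than one place, so no single change has yet been sized.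

The next member, compound 3 `Cc1ccc2nc(-c3cccc(C(F)(F)F)c3)[nH]c(=O)c2c1`, differs from compound 1 by trifluoromethyl in place of fluoro on an aromatic carbon. Going by the values given here, with no measured step to guide it, the change from compound 1 to compound 3 in this assay is expected to be small, a number 4.9 percentage points lower from compound 1 to compound 3 (within the scatter), with no move beyond the scatter, because compound 1 already gives 82.9% at the single concentration tested. Compound 3 is therefore estimated at 78% in this assay, with a range from 60% to 92%.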

Compound 3, a percentage reported as inhibition, at one concentration (the size of the read-out at that concentration, not a potency): 45.8%
Compound 3: middle estimate off by 32.2 percentage points, on the high side, and the stated range ends above it.
By their numbers in this assay, from the lowest: compound 3; then compounds 2 and 1 (each within the scatter of the next).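

For the compounds shown here, on the six-membered aromatic ring of carbon only, at the carbon meta to a large group, trifluoromethyl in place of fluoro gives a number 37.1 percentage points lower from compound 1 to compound 3 (beyond the scatter) in this assay and so sizes the first single change. This position is therefore not indifferent to what it carries: the group grows from 1 heavy atom to 4 heavy atoms, with 0 hydrogen-bond donors, 0 hydrogen-bond acceptors and no net charge on either side, and the read-out at the one concentration tested drops well past what repeated measurements would scatter. Nothing measured here accounts for the drop.

The compounds shown leave open whether a chloro group, a methoxy group or an amine at this same carbon would stay close to fluoro or fall as far as trifluoromethyl in this assay at the same concentration. Also open, from the compounds shown here alone, is whether the step keeps its size on a core carrying the diethylamino group of compound 2 in place of the methyl of compound 1.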